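Dichlorophenyl Urea Variant of a Quinoline Ether Series

A few compounds are considered here, and "the series" means these few. Any claim that something is new, unique, unknown or untested is made for them only; others in the source may bear on it.

Compound 2 `COc1cc2cc(Oc3ccc(NC(=O)Nc4cccc(C(F)(F)F)c4)cc3)c(C)nc2cc1OC` holds the lowest of the two numbers recorded in a functional assay on SK-MEL-28 cells (Homo sapiens) for inhibition, read by sulforhodamine B assay, with a stated time of 48 h, tested at 10 uM (a lower number here means a stronger effect, a higher number a weaker effect of the compound at the concentration tested), where compound 2 gives 26.7%; compound 1 `COc1cc2cc(Oc3ccc(NC(=O)Nc4ccc(C)cc4)cc3)c(C)nc2cc1OC` gives 109% in this assay. Going by the values given here, the single measured step, a number 82.3 percentage points lower from compound 1 to compound 2 (beyond the scatter), shows that the aryl group on the urea nitrogen moves the read-out strongly. Compound 3 `COc1cc2cc(Oc3ccc(NC(=O)Nc4ccc(Cl)c(Cl)c4)cc3)c(C)nc2cc1OC` differs from compound 2 by 3,4-dichlorophenyl in place of 3-(trifluoromethyl)phenyl on an amide-type nitrogen. Among the compounds with values here, no measured step covers this exact exchange, so the expectation leans on compound 2 itself, with a step of a number 3.3 percentage points higher from compound 2 to compound 3 (within the scatter) expected to stay within the scatter. Compound 3 is thus estimated at 30%, between 10% and 65%.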

Compound 3, a percentage reported as activity, at one concentration (the size of the read-out at that concentration, not a potency): 44.6%
Estimate against measurement, compound 3: 14.6 percentage points below; the range from low to high includes it.
By their numbers in this assay, from the lowest: compound 2; then compound 3; then compound 1.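

In this assay, the exchange on the amide-type nitrogen gives a number 17.9 percentage points higher from compound 2 to compound 3 (beyond the scatter) and so separates two aryl groups that both lie well under 4-methylphenyl. Against that group, 3,4-dichlorophenyl still gives a number 64.4 percentage points lower from compound 1 to compound 3 (beyond the scatter) and keeps most of the drop, so a low number at this position is not unique to 3-(trifluoromethyl)phenyl. Nothing available explains why these aryl groups differ.

The compounds shown leave open where a plain phenyl, a pyridyl ring or a cyclohexyl group on this nitrogen would fall.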